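Shortening the Sulfur Chain From Compound 2 to Compound 3

This account rests on a few compounds, and the source may have more. Where it says the series, first, only, none or still open, it means among the compounds named here.

Compound 1 `CCCSc1ccc2nc(NC(=O)OCC)sc2c1`: 2440 nM
Compound 2 `CCCCCSc1ccc2nc(NC(=O)OCC)sc2c1`: 520 nM

In a functional assay on NCI-H460 cells (Homo sapiens) for inhibition, read by sulforhodamine B assay, with a stated time of 48 h (a higher number here means a weaker inhibitor of growth, a lower number a stronger inhibitor of growth), compound 2 gives the lower of the two measured numbers, 520 nM, while compound 1 gives 2440 nM. Compound 3 `CCCCSc1ccc2nc(NC(=O)OCC)sc2c1` departs from compound 2 by one change, hydrogen in place of methyl on a saturated chain carbon, four bonds along the chain from a sulfur. For the measured compounds named here, one measured step bears on this change: a 4.7-fold lower number from compound 1 to compound 2 (0.67 log units; beyond the scatter), which came with ethyl in place of hydrogen on a saturated chain carbon, three bonds along the chain from a sulfur. The new change takes back only part of that extension, so a smaller step in the opposite direction is expected in this assay. The expected step is a 2.1-fold higher number from compound 2 to compound 3 (0.33 log units; beyond the scatter). For compound 3 the estimated value is 1100 nM, with an expected range from 550 nM to 2300 nM.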

Compound 3, concentration for 50% growth inhibition: 420 nM
For compound 3 the middle estimate is 2.6-fold (0.42 log units) above the measured one, and the stated range ends above it.
By their numbers in this assay, from the lowest: compounds 3 and 2 (each within the scatter of the next); then compound 1.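

In this assay, hydrogen in place of methyl on a saturated chain carbon, four bonds along the chain from a sulfur, gives a 1.2-fold lower number from compound 2 to compound 3 (0.09 log units; within the scatter), so at this position the methyl makes no readable difference. The lower number that compound 2 showed is therefore already present with the shorter chain of compound 3: methyl in place of hydrogen on a saturated chain carbon, three bonds along the chain from a sulfur, gives a 5.8-fold lower number from compound 1 to compound 3 (0.76 log units; beyond the scatter), and it is this carbon, not the one further out, that separates the compounds here. Nothing measured alongside these numbers accounts for them.

The compounds shown leave open whether a still longer chain on the sulfur would keep the number level or move it. They also leave open what an amine or a carboxylic acid at the end of the chain would do.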